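The source may report more compounds than this note shows. Statements on the series, on what has been measured and on what is new or still open speak of the compounds shown alone.

Compound 1 `O=C1C=C(NC2CCCCC2)C(=O)c2c1nc1n2[C@H]2OC[C@@H](O)[C@H]2OC1`: > 16000 nM, a limit
Compound 2 `Cc1ccc(NC2=CC(=O)c3nc4n(c3C2=O)[C@H]2OC[C@@H](O)[C@H]2OC4)cc1C`: 2690 nM
Compound 3 `Cc1ccc(NC2=CC(=O)c3nc4n(c3C2=O)[C@H]2OC[C@@H](O)[C@H]2OC4)cc1`: 3860 nM

In a functional assay on HeLa cells (Homo sapiens) for inhibition, read by sulforhodamine B assay (a lower number here means a stronger inhibitor, a higher number a weaker inhibitor), the entry for compound 1 is a limit of the assay and not a number: > 16000 nM. Compound 3 stands at 3860 nM and compound 2 at 2690 nM, two values within the scatter of each other. Both compounds carrying an aromatic ring on the amine nitrogen separate from the cyclohexyl compound: an at least 5.9-fold lower number from compound 1 to compound 2 (0.77 log units; beyond the scatter), and an at least 4.1-fold lower number from compound 1 to compound 3 (0.61 log units; beyond the scatter).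

The next compound is compound 4 `O=C1C=C(Nc2ccccc2)C(=O)c2c1nc1n2[C@H]2OC[C@@H](O)[C@H]2OC1`, which keeps an aromatic ring on that nitrogen. Its difference from compound 3 is hydrogen in place of methyl on an aromatic carbon, para to a large group, which turns 4-methylphenyl into phenyl. Within the data shown here, the one measured step of the same kind is a 1.4-fold higher number from compound 2 to compound 3 (0.16 log units; within the scatter), and it gives no sign of a large effect from removing a methyl. The steps from compound 1 bear only on the retained aromatic ring. In this assay, no shift beyond the scatter is therefore expected, and the expected step is a 1.2-fold higher number from compound 3 to compound 4 (0.07 log units; within the scatter). The estimated value for compound 4 is 4500 nM, with an expected range from 2200 nM to 9500 nM.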

Compound 4, half-maximal inhibitory concentration: 5620 nM
Compound 4: the middle estimate sits 1.2-fold (0.10 log units) below what was measured, and the stated range covers the measured number.
By their numbers in this assay, from the lowest: compounds 2, 3 and 4 (each within the scatter of the next, the first and the last beyond it). At a limit, above all of these: compound 1.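

In this assay, taking off the remaining methyl gives a 1.5-fold higher number from compound 3 to compound 4 (0.16 log units; within the scatter), so neither single methyl removal in the series moves the value beyond the scatter. The two methyl groups counted together do, with a 2.1-fold higher number from compound 2 to compound 4 (0.32 log units; beyond the scatter), which is a modest gap that shows only between the ends of the series, from 3,4-dimethylphenyl to phenyl. The plain phenyl ring, with no methyl at all, still separates from cyclohexyl on the amine nitrogen, with an at least 2.8-fold lower number from compound 1 to compound 4 (0.45 log units; beyond the scatter), a step read against a limit of the assay and not against a number: the limit of > 16000 nM in this assay, at which 1 of the 4 values shown sits.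

The compounds shown leave open whether a methoxy group, a chlorine atom or a carboxylic acid on the aromatic ring would behave as methyl does. They also leave open whether a benzyl group or an open alkyl chain on the amine nitrogen would fall with the aromatic compounds or with cyclohexyl.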